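Changing the Sulfonyl Group of Compound 3

The compounds below may be only part of what the source reports. "The series", "measured", "known", "first", "only" and "open" are said of these compounds alone.

In an ADME assay on microsomes (Mus musculus) for metabolic stability (a higher number here means faster removal of the compound, a lower number slower removal), compound 3 (`COC[C@@H]1CCCN1S(=O)(=O)c1ccc(Cl)c(COc2cccc3c(C(F)(F)F)cc(C)nc23)c1Cl`) gives 1620 mL/min/kg. Compound 1 (`CCc1cc(C(F)(F)F)c2cccc(OCc3c(Cl)ccc(S(=O)(=O)N4CCC[C@H]4C(=O)NC)c3Cl)c2n1`) gives 1280 mL/min/kg, a value within the scatter of that of compound 3. Compound 2 (`CNC(=O)[C@@H]1CCCN1S(=O)(=O)c1cccc(COc2cccc3c(C(F)(F)F)cc(C)nc23)c1`) gives 767 mL/min/kg, which is lower than the number for compound 3 by a gap beyond the scatter.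

The next compound to be read is compound 4 (`Cc1cc(C(F)(F)F)c2cccc(OCc3c(Cl)ccc(S(=O)(=O)N4CCC(C#N)CC4)c3Cl)c2n1`). It differs from compound 3 in one place, with 4-cyanopiperidin-1-yl in place of 2-(methoxymethyl)pyrrolidin-1-yl on a sulfonyl sulfur. Going by the values given here, no two measured compounds differ in only one place, so the data do not show the size of such a step directly. The nearest guide is compound 1, at 1280 mL/min/kg, which carries a different group on the sulfonyl sulfur, along with other differences, and still sits within the scatter of compound 3.

A small downward move in this assay is therefore expected, one that stays within the scatter, and the estimated step runs a 1.5-fold lower number from compound 3 to compound 4 (0.17 log units; within the scatter). For compound 4 the estimated clearance is 1100 mL/min/kg, with an expected range of 550 mL/min/kg to 1900 mL/min/kg.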

Compound 4, clearance: 1720 mL/min/kg
Compound 4: middle estimate off by 1.6-fold (0.19 log units), on the low side; the range from low to high includes it.
By their numbers in this assay, from the lowest: compounds 2, 1, 3 and 4 (each within the scatter of the next, the first and the last beyond it).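

In this assay, going by these compounds alone, the reading is a 1.1-fold higher number from compound 3 to compound 4 (0.03 log units; within the scatter), the first comparison in which only the group on the sulfonyl sulfur differs. In this assay, 4-cyanopiperidin-1-yl and 2-(methoxymethyl)pyrrolidin-1-yl therefore cannot be told apart, even though the exchange alters the ring from five-membered to six-membered, introduces a nitrile, and removes the defined stereocentre. The measurements shown offer no explanation for why these two groups read alike.

This single pair changes ring size, substituent and stereocentre together, so the compounds shown do not separate the contribution of each, and a plain piperidin-1-yl group on the same sulfur would be needed to isolate the nitrile. Going by these compounds, it also remains open whether a morpholin-4-yl or dimethylamino group at this position, or a carboxylic acid on the piperidine ring in place of the nitrile, would give a reading beyond the scatter of compound 3 and compound 4.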